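Lengthening the ester chain from compound 2 to compound 4

The compounds below may be only part of what the source reports. "The series", "measured", "known", "first", "only" and "open" are said of these compounds alone.

Compound 1 `C/C=C1/[C@H](O[C@@H]2O[C@H](CO)[C@@H](O)[C@H](O)[C@H]2O)OC=C(C(=O)OC)[C@H]1CC(=O)OCCc1ccc(O)c(O)c1` gives 160000 nM in a functional assay on SK-BR-3 cells (Homo sapiens) for antiproliferative activity, read by MTT assay, with a stated time of 72 h; a higher number here means a weaker inhibitor, a lower number a stronger inhibitor.
Compound 2 `C/C=C1/[C@H](O[C@@H]2O[C@H](CO)[C@@H](O)[C@H](O)[C@H]2O)OC=C(C(=O)OC)[C@H]1CC(=O)OCC` gives > 15000 nM in this assay, which is a limit of the assay.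
Compound 3 `C/C=C1/[C@H](O[C@@H]2O[C@H](COC(C)=O)[C@@H](OC(C)=O)[C@H](OC(C)=O)[C@H]2OC(C)=O)OC=C(C(=O)OC)[C@H]1CC(=O)OC` gives > 15000 nM in this assay, also a limit of the assay.

Compound 2 therefore stands only at the limit of > 15000 nM in this assay, at which 2 of the 3 values shown sit, and the step that the limit leaves unreadable from compound 1 to compound 2 cannot be sized. Compound 4 `C/C=C1/[C@H](O[C@@H]2O[C@H](CO)[C@@H](O)[C@H](O)[C@H]2O)OC=C(C(=O)OC)[C@H]1CC(=O)OCCCC` differs from compound 2 by ethyl in place of hydrogen on a saturated chain carbon, two bonds along the chain from an oxygen next to a carbonyl group. Among the compounds with values here, no measured step covers a change of this kind, so nothing in the data points to a direction or a size for it in this assay. Compound 4 is expected to stay at or near the limit, with an estimate of 20000 nM and a range from 8000 nM to 60000 nM. The step that the limit leaves unreadable from compound 2 to compound 4 is thus expected to be no larger than the scatter.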

Compound 4, half-maximal inhibitory concentration: > 15000 nM
Compound 4: a limit, no number (the forecaster's own chance of this, stated with the estimate: 70%); the middle value is on the limit's open side.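

Compound 4 gives > 15000 nM, which is a limit of the assay, so the steps to it from compound 1 and compound 2 cannot be read. The compounds shown leave open whether changing the ester chain on the shared core has any effect in this assay.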